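This account rests on a few compounds, and the source may have more. Where it says the series, first, only, none or still open, it means among the compounds named here.

Three analogues sharing one core have been run in a functional assay on HeLa cells (Homo sapiens) for inhibition, read by MTT assay, with a stated time of 72 h; a lower number here means a stronger inhibitor, a higher number a weaker inhibitor. Compound 1 `CN(C(=O)NC(=O)c1ccc(F)c(F)c1)c1nc(C(F)(F)F)c(C(=O)N/N=C/c2ccc(C(F)(F)F)cc2)s1` gives 5.1 ug/mL, compound 2 `CN(C(=O)NC(=O)c1cccc(C(F)(F)F)c1)c1nc(C(F)(F)F)c(C(=O)N/N=C/c2ccc(C(F)(F)F)cc2)s1` gives 7.35 ug/mL, and compound 3 `CN(C(=O)NC(=O)c1cccc(C(F)(F)F)c1)c1nc(C(F)(F)F)c(C(=O)N/N=C/c2ccccc2C(F)(F)F)s1` gives 7.37 ug/mL. Compound 3 holds the highest of the three numbers, though its gap to compound 2 is nil and its gap to compound 1 is within the scatter, so no order among them is claimed. Compound 4 `CN(C(=O)NC(=O)c1ccc(F)c(F)c1)c1nc(C(F)(F)F)c(C(=O)N/N=C/c2ccccc2C(F)(F)F)s1` is the next member, differing from compound 3 by 3,4-difluorophenyl in place of 3-(trifluoromethyl)phenyl on a carbonyl carbon. The same exchange, run the other way, gave a 1.4-fold higher number from compound 1 to compound 2 (0.16 log units; within the scatter), while a 1.0-fold higher number from compound 2 to compound 3 (0.00 log units; within the scatter) showed the other ring position to be indifferent. No shift beyond the scatter is therefore expected; compound 4 is estimated at 5.2 ug/mL (range 3 ug/mL to 9 ug/mL), a step of a 1.4-fold lower number from compound 3 to compound 4 (0.15 log units; within the scatter).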

Compound 4, half-maximal inhibitory concentration: 9.24 ug/mL
Compound 4: the middle estimate sits 1.8-fold (0.25 log units) below what was measured; measured number outside the range, above it.
By their numbers in this assay, from the lowest: compounds 1, 2, 3 and 4 (each within the scatter of the next).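

In this assay, 3,4-difluorophenyl in place of 3-(trifluoromethyl)phenyl on a carbonyl carbon gives a 1.3-fold higher number from compound 3 to compound 4 (0.10 log units; within the scatter), so this exchange, now read on a second core, shows no shift beyond the scatter on either: the same change on two cores in this assay, a 1.4-fold higher number (0.16 log units; within the scatter) from compound 1 to compound 2 and a 1.3-fold lower number (0.10 log units; within the scatter) from compound 4 to compound 3, 1.8-fold (0.26 log units) apart, within the scatter of two such steps With 3,4-difluorophenyl on the carbonyl carbon, 2-(trifluoromethyl)phenyl in place of 4-(trifluoromethyl)phenyl gives a 1.8-fold higher number from compound 1 to compound 4 (0.26 log units; within the scatter), and this exchange likewise stays within the scatter on both cores: the same change on two cores in this assay, a 1.0-fold higher number (0.00 log units; within the scatter) from compound 2 to compound 3 and a 1.8-fold higher number (0.26 log units; within the scatter) from compound 1 to compound 4, 1.8-fold (0.26 log units) apart, within the scatter of two such steps Across these compounds, neither place has yet moved the number beyond the scatter. Still open, going by these compounds, is whether a phenyl bearing an amine or a carboxylic acid on the carbonyl carbon would do so.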